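Aryl urea variation across a shared core

The source may hold more compounds than are shown below. What is called first, only, known or untested is meant among the compounds shown, and "the series" means these compounds.

Measured so far:
- compound 1 `COc1cc(NC(C)CCCNC(=O)Nc2ccc(F)cc2)c2ncccc2c1`: in a functional assay on MOLT-4 cells (Homo sapiens) for inhibition, read by MTT assay, with a stated time of 72 h (on this read-out lower numbers stand for stronger inhibition and higher numbers for weaker inhibition), compound 1 gives 24000 nM
- compound 2 `COc1cc(NC(C)CCCNC(=O)Nc2ccc(C(F)(F)F)cc2)c2ncccc2c1`: in this assay compound 2 gives 20000 nM
- compound 3 `COc1cc(NC(C)CCCNC(=O)NNC(=O)Nc2ccc(O)cc2)c2ncccc2c1`: in this assay compound 3 gives 104000 nM

Compound 1 stands second highest of the three numbers in this assay. Its nearest neighbour is compound 2, reached by a 1.2-fold lower number from compound 1 to compound 2 (0.08 log units; within the scatter), which is within the scatter. Its furthest is compound 3, reached by a 4.3-fold higher number from compound 1 to compound 3 (0.64 log units; beyond the scatter), which is beyond the scatter. The step from compound 2 to compound 3 is a 5.2-fold higher number from compound 2 to compound 3 (0.72 log units; beyond the scatter), also beyond the scatter.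

Compound 4 `COc1cc(NC(C)CCCNC(=O)Nc2cccc(F)c2)c2ncccc2c1` differs from compound 1 in one place: 3-fluorophenyl in place of 4-fluorophenyl on an amide-type nitrogen. Among the compounds with values here, no measured step moves a fluorine around the same ring. The closest comparison is a 1.2-fold lower number from compound 1 to compound 2 (0.08 log units; within the scatter), where the substituent on the aryl group was exchanged and the number did not move beyond the scatter. The two steps beyond the scatter, a 4.3-fold higher number from compound 1 to compound 3 (0.64 log units; beyond the scatter) and a 5.2-fold higher number from compound 2 to compound 3 (0.72 log units; beyond the scatter), involve a much larger replacement on the amide-type nitrogen and do not bear directly on a shift of one fluorine. The expectation is therefore a step of no size beyond the scatter, estimated as no change at the digits printed from compound 1 to compound 4 (within the scatter). Compound 4 is expected to give about 24000 nM, in a range from 10000 nM to 60000 nM.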

Compound 4, half-maximal inhibitory concentration: 23000 nM
Beside the measured number, compound 4's estimate is 1.0-fold (0.02 log units) above it; the range from low to high includes it.
By their numbers in this assay, from the lowest: compounds 2, 4 and 1 (each within the scatter of the next); then compound 3.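

In this assay, within the data shown here, 3-fluorophenyl in place of 4-fluorophenyl on the amide-type nitrogen gives a 1.0-fold lower number from compound 1 to compound 4 (0.02 log units; within the scatter) and stays within the scatter, which is the first reading of a shift of the fluorine around the same ring. Compound 4 also joins the trifluoromethyl compound, with a 1.2-fold higher number from compound 2 to compound 4 (0.06 log units; within the scatter) again within the scatter, so the three aryl ureas, compounds 1, 2 and 4, now stand as one cluster whichever of these three aryl groups is present. Among these compounds, the separation from the ((4-hydroxyphenyl)carbamoyl)amino replacement holds for this new aryl group too, with a 4.5-fold lower number from compound 3 to compound 4 (0.66 log units; beyond the scatter) beyond the scatter, and that replacement remains the only change that moves the number beyond the scatter.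

Going by these compounds, whether an amine or a carboxylic acid on the aryl ring, or a longer chain in place of the one joining the urea to the shared core, would shift the number beyond the scatter stays open. Nothing in the available evidence speaks to why the numbers fall as they do.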